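Trimming one methoxy from compound 2

The compounds below may be only part of what the source reports. "The series", "measured", "known", "first", "only" and "open" are said of these compounds alone.

Working notes on a short series of three measured compounds and one still open. Compound 1 `COc1ccc(-c2cc(/C=C/C(=O)c3ccc(N)cc3)[nH]n2)cc1` gives 93% in a functional assay on PC-3 cells (Homo sapiens) for cytotoxicity, read by sulforhodamine B assay, with a stated time of 48 h, tested at 0.1 uM; on this read-out higher numbers stand for a weaker effect at the one concentration tested and lower numbers for a stronger effect. Compound 2 `COc1cc(-c2cc(/C=C/C(=O)c3ccc(N)cc3)[nH]n2)cc(OC)c1OC` gives 94% in this assay, which places it second highest of the three numbers, with compound 1 nearest and compound 3 furthest, both within the scatter. Within the data shown here, compound 3 `COc1ccc(C(=O)/C=C/c2cc(-c3cc(OC)c(OC)c(OC)c3)n[nH]2)cc1OC` gives 95% in this assay; the only one-place step among the measured compounds, a number 1 percentage points higher from compound 2 to compound 3 (within the scatter), changes the group on the carbonyl carbon and stays within the scatter.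

Compound 4 `COc1ccc(-c2cc(/C=C/C(=O)c3ccc(N)cc3)[nH]n2)cc1OC` differs from compound 2 by hydrogen in place of methoxy on an aromatic carbon. Among the measured compounds shown here, no measured step touches this ring, so none bears directly on the change; compound 1 and compound 2 carry different methoxy counts on that ring, and compound 1 shows 93% while compound 2 shows 94%, a pair within the scatter. For the measured compounds named here, the single step that is known, a number 1 percentage points higher from compound 2 to compound 3 (within the scatter), is also flat. For compound 4 a step of no change at the digits printed from compound 2 to compound 4 (within the scatter) is therefore expected, none beyond the scatter, and compound 4 is estimated at 94% with a range of 84% to 100%.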

Compound 4, a percentage reported as activity, at one concentration (the size of the read-out at that concentration, not a potency): 95%
Beside the measured number, compound 4's estimate is 1 percentage points below it; measured number inside the range.
By their numbers in this assay, from the lowest: compounds 1, 2, 3 and 4 (each within the scatter of the next).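

Hydrogen in place of methoxy at this position, ortho to a methoxy group, gives a number 1 percentage points higher from compound 2 to compound 4 (within the scatter), the first measured one-place step on this ring. Methoxy in place of hydrogen on an aromatic carbon of the same ring gives a number 2 percentage points higher from compound 1 to compound 4 (within the scatter), so in this assay both methoxy changes on this ring stay within the scatter, and compounds 1, 2 and 4 cannot be told apart at the one concentration tested. Nothing among the data speaks to why these steps read as flat.

From the compounds shown here alone, whether a hydroxyl, an amine or a longer chain such as ethoxy at this position would also stay within the scatter remains open. Also open, going by these compounds, is whether compounds 1, 2 and 4 would separate at another concentration, since a single-concentration read-out gives no potency.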